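Working notes: one chain change from compound 1 to compound 3

This account rests on a few compounds, and the source may have more. Where it says the series, first, only, none or still open, it means among the compounds named here.

In a functional assay on SK-MEL-2 cells (Homo sapiens) for cytotoxicity (on this read-out lower numbers stand for an effect already at smaller amounts and higher numbers for an effect only at larger amounts of compound), compound 1 (`C#C/C=C\CCCCCCCCCCCCCC/C=C/CCCC/C=C/CCCCC#C[C@@H](O)C#CCCCCCC/C=C/[C@H](O)C#C`) gives 1.1 ug/mL and compound 2 (`C#C/C=C\CCCCCCCCCCCCCC/C=C/CCCC/C=C/CC/C=C/C#C[C@@H](O)C#CCCCCCC/C=C/[C@H](O)C#C`) gives 0.9 ug/mL on the same read-out. For the measured compounds named here, these two numbers lie within the usual scatter of each other, so compound 1 stands level with the only other measured compound and the two cannot be ranked.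

Compound 3 (`C#C/C=C\CCCCCCCCCCCCCC/C=C/CCCC/C=C/CCCCC#C[C@@H](O)C#CCCCCCCCC[C@H](O)C#C`) is not yet measured and differs from compound 1 in one place: a group of 6 heavy atoms (5 carbon, 1 oxygen; no ring) in place of a group of 6 heavy atoms (5 carbon, 1 oxygen; no ring), on a saturated chain carbon, six bonds along the chain from a triple-bonded carbon in the long chain. The group that leaves holds a double bond and a triple bond, while the group that enters holds the triple bond only.

Going by the values given here, no measured pair differs in a single place, so no direct step exists for this change. Among the compounds with values here, the only guide is that compound 2 at 0.9 ug/mL and compound 1 at 1.1 ug/mL sit within the scatter of each other. No shift beyond the scatter is expected in this assay for this change. The expected size is a 1.2-fold higher number from compound 1 to compound 3 (0.07 log units; within the scatter) and it leans only slightly toward a higher number. Compound 3 is estimated at 1.3 ug/mL with an expected range from 0.5 ug/mL to 3.5 ug/mL on this read-out.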

Compound 3, concentration for half-maximal effect: 1.9 ug/mL
Compound 3: the middle estimate sits 1.5-fold (0.16 log units) below what was measured; the measured number falls inside the stated range.
By their numbers in this assay, from the lowest: compounds 2, 1 and 3 (each within the scatter of the next, the first and the last beyond it).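

In this assay the series now has its first step that changes a single place: the group holding a double bond and a triple bond gives way to the group holding the triple bond only, on a saturated chain carbon, six bonds along the chain from a triple-bonded carbon, and this gives a 1.7-fold higher number from compound 1 to compound 3 (0.24 log units; within the scatter) on this read-out. The double bond of the leaving group can therefore be lost at this position with no shift beyond the scatter, and compound 3 stands level with compound 1. No measurement at hand gives any reason for this outcome.

The compounds shown leave open whether a different group at this place, such as an amine, a carboxylic acid or a longer chain, would move the number beyond the scatter. On these data alone, it also remains open whether the same change, made on compound 2 instead of compound 1, would give a step of similar size, as one step on one parent cannot settle that.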